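Two dithiocarbamates and a smaller analogue on breast-cancer cells

The source may report more compounds than this note shows. Statements on the series, on what has been measured and on what is new or still open speak of the compounds shown alone.

Compound 1 `CCNC(=S)SCC1=CCOC1=O` is a dithiocarbamate ester attached to a butenolide core, with an ethyl group on the amide-type nitrogen. In a functional assay on MCF7 cells (Homo sapiens) for antiproliferative activity, read by MTT assay, with a stated time of 72 h (on this read-out higher numbers stand for weaker inhibition and lower numbers for stronger inhibition), compound 1 gives 80100 nM. Compound 2 `O=C1OCC=C1CSC(=S)NC1CC1` keeps the same core and carries a cyclopropyl group in place of the ethyl. In this assay compound 2 gives 94900 nM. The step of a 1.2-fold higher number from compound 1 to compound 2 (0.07 log units; within the scatter) shows that swapping ethyl for cyclopropyl did not move the number beyond the usual scatter. Among the compounds with values here, compound 2 thus has the higher of the two numbers measured so far, but its only neighbour, compound 1, sits within the scatter of it.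

Compound 3 `CNC(=S)SCC1=CCOC1=O` differs from compound 2 by methyl in place of cyclopropyl on an amide-type nitrogen. Within the data shown here, the only measured step that bears on this position, from compound 1 to compound 2, was within the scatter, so a change on the same nitrogen to an even smaller group is expected to give a step of no more than a 1.0-fold higher number from compound 2 to compound 3 (0.00 log units; within the scatter), with no clear direction. Compound 3 is therefore estimated at 95000 nM, in a range from 45000 nM to 200000 nM.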

Compound 3, half-maximal inhibitory concentration: 83100 nM
Estimate against measurement, compound 3: 1.1-fold (0.06 log units) above, within the range that was stated.
By their numbers in this assay, from the lowest: compounds 1, 3 and 2 (each within the scatter of the next).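

The comparison now covers three groups on the amide-type nitrogen rather than one swap. The step of a 1.1-fold lower number from compound 2 to compound 3 (0.06 log units; within the scatter) and the step of a 1.0-fold higher number from compound 1 to compound 3 (0.02 log units; within the scatter) both lie within the scatter, so in this assay methyl, ethyl and cyclopropyl cannot be told apart at this position. The step from compound 2 to compound 3 also removes the three-membered ring, and for these compounds, the number stays within the scatter without that ring. Nothing available here offers an explanation for how closely these three numbers sit.

All three groups are small carbon groups, so these compounds cover only a narrow part of what could sit on this nitrogen, and a longer chain such as hexyl, a benzyl group, or a chain ending in an amine or a carboxylic acid could give a quite different number. They also leave open whether a change elsewhere, in the dithiocarbamate link or in the shared core, would move the number beyond the scatter.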